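The source may report more compounds than this note shows. Statements on the series, on what has been measured and on what is new or still open speak of the compounds shown alone.

Compound 1 `Cc1ccsc1-c1cc(-c2ccco2)cc(-c2ccc(Cl)cc2)n1` and compound 2 `Clc1ccc(-c2cc(-c3ccco3)cc(-c3ccc(Cl)s3)n2)cc1` share a core that carries a 4-chlorophenyl group and a furan-2-yl group. In a functional assay on HCT-15 cells (Homo sapiens) for cytotoxicity, read by ELISA, with a stated time of 4 days (a higher number here means a weaker inhibitor, a lower number a stronger inhibitor), compound 1 gives 710 nM, and compound 2 gives 1080 nM. The change between them is 5-chlorothiophen-2-yl in place of 3-methylthiophen-2-yl on an aromatic carbon, and it made a step of a 1.5-fold higher number from compound 1 to compound 2 (0.18 log units; within the scatter).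

Compound 3 `Cc1ccsc1-c1cc(-c2ccc(Cl)o2)cc(-c2ccco2)n1` has a core that differs from the core of compound 1; that difference is not broken down here. In this assay compound 3 gives 26300 nM, which stands beyond the scatter from both compound 1 and compound 2.

For the measured compounds named here, compound 4 `Clc1ccc(-c2cc(-c3ccco3)nc(-c3ccc(Cl)s3)c2)o1` has no measurement yet. It differs from compound 3 by 5-chlorothiophen-2-yl in place of 3-methylthiophen-2-yl on an aromatic carbon. Going by the values given here, this is the same kind of change as the one between compound 1 and compound 2, but not the same: in compound 1 the place is meta to a 4-chlorophenyl group, whereas in compound 3 it is meta to a 5-chlorofuran-2-yl group. The earlier step of a 1.5-fold higher number from compound 1 to compound 2 (0.18 log units; within the scatter) lay within the scatter. On that basis the step expected here is a 1.2-fold higher number from compound 3 to compound 4 (0.09 log units; within the scatter). Compound 4 is therefore estimated at 32000 nM, with a likely range from 10000 nM to 100000 nM.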

Compound 4, half-maximal inhibitory concentration: > 50000 nM
Compound 4: no number, only a limit; the forecaster's own chance of this, stated with the estimate: 15%; at least 1.5-fold (0.19 log units) between middle value and limit.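

In this assay compound 4 gives > 50000 nM, which is a limit of the assay and not a number. The exchange of 3-methylthiophen-2-yl for 5-chlorothiophen-2-yl therefore reads only as a floor, an at least 1.9-fold higher number from compound 3 to compound 4 (0.27 log units; that floor lies within the scatter), and set beside the earlier step it does not settle whether the change behaves alike on the two cores: the same change on two cores in this assay, a 1.5-fold higher number (0.18 log units; within the scatter) from compound 1 to compound 2 and an at least 1.9-fold higher number (0.27 log units; that floor lies within the scatter) from compound 3 to compound 4; the limit leaves it open whether they differ. The result thus fits a step of the small size seen on the core of compound 1 and also a larger one, so it neither shows that the change carries over unaltered nor shows that it does not, and the reading stops at the top of the range: the limit of > 50000 nM in this assay, at which 1 of the 4 values shown sits.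

From the compounds shown here alone, an exact value for compound 4 remains open, and with it the true size of the step on this core. Also open, going by these compounds, is how either core would respond to an amine or a carboxylic acid in place of the 5-chlorothiophen-2-yl group.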